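Adding a Methylamino Pyridine to the Pyrazole Carboxylic Acid

The source may report more compounds than this note shows. Statements on the series, on what has been measured and on what is new or still open speak of the compounds shown alone.

Compound 1 `COc1cccc(-c2c(C)nn(-c3nc(-c4ccc(Cl)c(Cl)c4)c(SC(C)C)s3)c2C(=O)O)c1` gives 14000 nM in a functional assay on BJAB cells (Homo sapiens) for antiproliferative activity, with a stated time of 4 days; on this read-out higher numbers stand for an effect only at larger amounts of compound and lower numbers for an effect already at smaller amounts.
Compound 2 `COc1cc(-c2c(C)nn(-c3nc(-c4ccc(Cl)c(Cl)c4)c(SC(C)C)s3)c2C(=O)O)cc(C(F)(F)F)c1` gives 1380 nM in this assay.
Compound 3 `Cc1nn(-c2nc(-c3ccc(Cl)c(Cl)c3)c(SC(C)C)s2)c(C(=O)O)c1-c1cccnc1` gives 12000 nM in this assay.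

Compound 3 stands second highest of the three numbers in this assay; it sits close to compound 1, with a 1.2-fold lower number from compound 1 to compound 3 (0.07 log units; within the scatter), and far from compound 2, with an 8.7-fold higher number from compound 2 to compound 3 (0.94 log units; beyond the scatter). Compound 4 `CNc1cc(-c2c(C)nn(-c3nc(-c4ccc(Cl)c(Cl)c4)c(SC(C)C)s3)c2C(=O)O)ccn1` is not yet measured. It differs from compound 3 in one place: 2-(methylamino)pyridin-4-yl in place of pyridin-3-yl on an aromatic carbon. Among the measured compounds shown here, no measured step places a methylamino group on this ring, so the only guidance is indirect. The step of a 10-fold lower number from compound 1 to compound 2 (1.01 log units; beyond the scatter) shows that decorating the aryl group at this position can move the number greatly, while a 1.2-fold lower number from compound 1 to compound 3 (0.07 log units; within the scatter) shows that swapping one plain aromatic ring for another need not. Because the one substituent added in a 10-fold lower number from compound 1 to compound 2 (1.01 log units; beyond the scatter) lowered the number, compound 4 is expected to give a somewhat lower number than compound 3, with wide uncertainty, as a 2.0-fold lower number from compound 3 to compound 4 (0.30 log units; within the scatter). The estimate for compound 4 in this assay is 6000 nM, within a range from 1500 nM to 25000 nM.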

Compound 4, half-maximal effective concentration: 18000 nM
The estimate for compound 4 lay 3.0-fold (0.48 log units) below the measured number, within the range that was stated.
By their numbers in this assay, from the lowest: compound 2; then compounds 3, 1 and 4 (each within the scatter of the next).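

Placing 2-(methylamino)pyridin-4-yl at this position in place of pyridin-3-yl leaves the number in this assay within the scatter (a 1.5-fold higher number from compound 3 to compound 4 (0.18 log units; within the scatter)), so adding a methylamino group to a pyridine ring does not reproduce the low number of compound 2. Among the compounds shown here, the comparison with 3-methoxyphenyl also lies within the scatter (a 1.3-fold higher number from compound 1 to compound 4 (0.11 log units; within the scatter)), whereas compound 2 remains clearly apart (a 13-fold higher number from compound 2 to compound 4 (1.12 log units; beyond the scatter)), and it is the only one of the four compounds whose number stands beyond the scatter from all the others. No measurement given here explains why compound 2 stands apart from the other three.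

From the compounds shown here alone, whether a trifluoromethyl group on a pyridine ring would lower the number as it does on the 3-methoxyphenyl ring remains open. Going by these compounds, it is equally open whether a nitrile or a primary amine on that 3-methoxyphenyl ring would produce a step of similar size.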